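The compounds below may be only part of what the source reports. "The series", "measured", "known", "first", "only" and "open" are said of these compounds alone.

Series notes. Two members of the series have been measured in a functional assay on COLO 205 cells (Homo sapiens) for inhibition, read by sulforhodamine B assay, with a stated time of 48 h; a higher number here means a weaker inhibitor of growth, a lower number a stronger inhibitor of growth. Compound 1 `COc1cc(-c2nn(-c3cccc(NC(=O)c4cccc(C(F)(F)F)c4)c3)cc2-c2ccncc2)ccc1Cl` gives 5170 nM in this assay. Compound 2 `O=C(Nc1cccc(-n2cc(-c3ccncc3)c(-c3ccc(Cl)c(O)c3)n2)c1)Nc1cc(C(F)(F)F)cc(C(F)(F)F)c1` gives 1580 nM in this assay, and the gap between these two numbers lies beyond the usual scatter, so compound 1 stands as the higher of the two values, that is, the weaker inhibitor of growth on the numbers in hand. No pair of these compounds differs in one place only, so the two values show a comparison of the whole molecules and nothing finer.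

Compound 3 `COc1cc(-c2nn(-c3cccc(NC(=O)c4ccccc4)c3)cc2-c2ccncc2)ccc1Cl` is not yet measured in this assay. It differs from compound 1 in one place: hydrogen in place of trifluoromethyl on an aromatic carbon. For the measured compounds named here, nothing measured isolates this change, so the expected size of the step rests on the single value of compound 1 alone. On that basis, compound 3 is expected to give a somewhat higher number than compound 1, a step of a 2.3-fold higher number from compound 1 to compound 3 (0.37 log units; beyond the scatter) in this assay, beyond the scatter but not large. The estimate for compound 3 in this assay is 12000 nM, with a range from 4000 nM to 40000 nM.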

Compound 3, concentration for total growth inhibition: 3230 nM
Estimate against measurement, compound 3: 3.7-fold (0.57 log units) above; measured number below the stated range.
By their numbers in this assay, from the lowest: compound 2; then compounds 3 and 1 (each within the scatter of the next).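

Hydrogen in place of trifluoromethyl on this aromatic carbon gives a 1.6-fold lower number from compound 1 to compound 3 (0.20 log units; within the scatter) in this assay and is the first comparison in the series that isolates a single place, so compound 1 and compound 3 cannot be separated on these numbers. Within this pair, the trifluoromethyl group is therefore not required for growth inhibition at the level seen, and the plain benzoyl of compound 3 serves as well as the (3-(trifluoromethyl)phenyl)carbonyl of compound 1 in this read-out. No independent measurement bears on why the two values fall so close together.

This single replacement leaves open whether a different group on the same aromatic carbon, such as an amine, a carboxylic acid or a nitrile, would give a step beyond the scatter. For the compounds shown here, compound 2 differs from compound 1 and from compound 3 in more than one place, so no step to it can be read and its lower number cannot be assigned to any one part of its structure.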